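Moving the nitrile: 4-cyanophenyl to 3-cyanophenyl

The compounds below may be only part of what the source reports. "The series", "measured", "known", "first", "only" and "open" are said of these compounds alone.

In a functional assay on SH-SY5Y cells (Homo sapiens) for antiproliferative activity, read by MTT assay, with a stated time of 72 h (a higher number here means a weaker inhibitor, a lower number a stronger inhibitor), compound 1 `COc1cc2c(Nc3ccc(C#N)cc3)ncnc2cc1OCCCN(C)Cc1ccccc1` gives > 100000 nM, which is a limit of the assay. Within the data shown here, compound 2 `CCN1CCN(CCCOc2cc3ncnc(Nc4ccc(C#N)cc4)c3cc2OC)CC1` gives 5440 nM, the only actual number so far. Compound 3 `CCN1CCN(CCCOc2cc3ncnc(Nc4cccc(C#N)c4)c3cc2OC)CC1` carries 3-cyanophenyl in place of 4-cyanophenyl on a nitrogen on an aromatic ring. Among the measured compounds shown here, the one measured step, an at least 18-fold lower number from compound 1 to compound 2 (1.26 log units; beyond the scatter), is large but lies on the saturated chain, not at this place, so it gives no direct guide to size here. No change beyond the scatter is expected, in either direction, and the estimated step is a 1.1-fold higher number from compound 2 to compound 3 (0.04 log units; within the scatter). Compound 3 is estimated at 6000 nM, with an expected range of 1800 nM to 20000 nM.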

Compound 3, half-maximal inhibitory concentration: 6270 nM
The estimate for compound 3 lay 1.0-fold (0.02 log units) below the measured number; the measured number falls inside the stated range.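

In this assay, moving the nitrile gives a 1.2-fold higher number from compound 2 to compound 3 (0.06 log units; within the scatter), so on a nitrogen on an aromatic ring, 3-cyanophenyl and 4-cyanophenyl are not told apart in this read-out. With 4-ethylpiperazin-1-yl on the chain, the nitrile tolerates either placement, at least between these two groups. Nothing at hand bears on why the two compounds read alike. Open, from the compounds shown here alone, is how 2-cyanophenyl, plain phenyl, or a carboxylic acid or an amine in place of the nitrile would read here. Also open, going by these compounds, is whether this tolerance holds with a longer chain.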